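Shortening the amine side chain in two dopamine transporter series

The source may hold more compounds than are shown below. What is called first, only, known or untested is meant among the compounds shown, and "the series" means these compounds.

Compound 1 `c1ccc(CCCN2CCC(CCOC(c3ccccc3)c3ccccc3)CC2)cc1` and compound 2 `c1ccc(CN2CCC(CCOC(c3ccccc3)c3ccccc3)CC2)cc1` share one core and differ in a single place. In an assay on striatum for binding affinity to sodium-dependent dopamine transporter (Rattus norvegicus) (on this read-out lower numbers stand for stronger inhibition and higher numbers for weaker inhibition), compound 1 gives 12 nM, and compound 2 gives 15.2 nM. The change between them is phenyl in place of phenethyl on a saturated chain carbon bound to an amine nitrogen in a ring, and it made a 1.3-fold higher number from compound 1 to compound 2 (0.10 log units; within the scatter). Compound 3 `Fc1ccc(C(OCC2CCN(CCCc3ccccc3)CC2)c2ccc(F)cc2)cc1` carries a second core; how this core differs from the core of compound 1 is not broken down here. In this assay compound 3 gives 13 nM, a number that sits within the scatter of those for compound 1 and compound 2. Compound 4 `Fc1ccc(C(OCC2CCN(Cc3ccccc3)CC2)c2ccc(F)cc2)cc1` has not yet been measured. For the measured compounds named here, it differs from compound 3 by phenyl in place of phenethyl on a saturated chain carbon bound to an amine nitrogen in a ring, and as the place is described in identical words, this is the same change as the one from compound 1 to compound 2. Because a 1.3-fold higher number from compound 1 to compound 2 (0.10 log units; within the scatter) stayed within the scatter, the same change on the second core is expected to bring a similarly small step. The expected step is a 1.2-fold higher number from compound 3 to compound 4 (0.09 log units; within the scatter). Compound 4 is therefore estimated at 16 nM, with a likely range from 7 nM to 36 nM.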

Compound 4, half-maximal inhibitory concentration: 126 nM
Beside the measured number, compound 4's estimate is 7.9-fold (0.90 log units) below it; the measured number lies above the stated range.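

In this assay, replacing phenethyl with phenyl at this place on the core of compound 3, which can also be read as 3-phenylpropyl to benzyl, gives a 9.7-fold higher number from compound 3 to compound 4 (0.99 log units; beyond the scatter). The same written change therefore does not carry the same size of step from one core to the other, and a small step on one core gave no safe guide to the step on the second: the same change on two cores in this assay, a 1.3-fold higher number (0.10 log units; within the scatter) from compound 1 to compound 2 and a 9.7-fold higher number (0.99 log units; beyond the scatter) from compound 3 to compound 4, 7.7-fold (0.88 log units) apart, beyond the scatter of two such steps. For the compounds shown here, this shows that the core matters to the outcome, but it does not show which structural difference between the two cores is responsible, and with only one pair on each core it sets no rule for any other core.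

Going by these compounds, it remains open whether a core carrying only one of the differences between these two cores would show the small step or the large one. On these data alone, it is also open how a longer chain, such as 4-phenylbutyl, would behave at the same place on each core.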